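Chain extension on a stilbene-type scaffold and its effect

This account rests on a few compounds, and the source may have more. Where it says the series, first, only, none or still open, it means among the compounds named here.

The series rests on three measured compounds. Compound 1 `CC=C(/C=C/c1ccc(OC)c(N)c1)c1cc(OC)c(OC)c(OC)c1` gives 247 nM in a functional assay on MCF7 cells (Homo sapiens) for antiproliferative activity, read by MTT assay, with a stated time of 48 h; a lower number here means a stronger inhibitor, a higher number a weaker inhibitor. Compound 2 `CCC=C(/C=C/c1ccc(OC)c(N)c1)c1cc(OC)c(OC)c(OC)c1` carries methyl in place of hydrogen on a saturated chain carbon bound to a double-bonded chain carbon and gives 486 nM in this assay; the step of a 2.0-fold higher number from compound 1 to compound 2 (0.29 log units; within the scatter) is small. Compound 3 `CCC=C(/C(C)=C/c1ccc(OC)c(O)c1)c1cc(OC)c(OC)c(OC)c1` is built on a different core, and the difference between the two cores is not broken down here; in this assay compound 3 gives 8250 nM, the highest number of the three.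

Compound 4 `CCCC=C(/C(C)=C/c1ccc(OC)c(O)c1)c1cc(OC)c(OC)c(OC)c1` has not yet been measured. It differs from compound 3 by methyl in place of hydrogen on a saturated chain carbon, two bonds along the chain from a double-bonded chain carbon, the same kind of change as that from compound 1 to compound 2, though it sits two bonds along the chain from the double-bonded carbon rather than bound to it. Because the earlier step of a 2.0-fold higher number from compound 1 to compound 2 (0.29 log units; within the scatter) stayed within the scatter, the expected step of a 1.5-fold higher number from compound 3 to compound 4 (0.16 log units; within the scatter) is modest as well. On that basis compound 4 is estimated to give about 12000 nM in this assay, most likely between 5000 nM and 30000 nM.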

Compound 4, half-maximal inhibitory concentration: 3970 nM
For compound 4 the middle estimate is 3.0-fold (0.48 log units) above the measured one; the whole stated range lies above it.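

In this assay the new step is a 2.1-fold lower number from compound 3 to compound 4 (0.32 log units; beyond the scatter). Set beside the earlier step, the change does not carry over unchanged from one core to the other, since the two steps point in opposite directions and differ in size: the same change on two cores in this assay, a 2.0-fold higher number (0.29 log units; within the scatter) from compound 1 to compound 2 and a 2.1-fold lower number (0.32 log units; beyond the scatter) from compound 3 to compound 4, 4.1-fold (0.61 log units) apart, beyond the scatter of two such steps This shows only that the outcome of this kind of change cannot be taken from one core to the other in this series; it rests on one pair per core, the change sits at a different place in each pair, and it does not show whether the cores or the place account for the gap.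

The compounds shown leave open whether a longer chain in place of the propyl would continue the step seen on the core of compound 3, or whether a carboxylic acid there would be tolerated. They also leave open how the same change would behave at the other place on each core.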